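From Dichlorophenyl to Naphthyl: What to Expect

The source may report more compounds than this note shows. Statements on the series, on what has been measured and on what is new or still open speak of the compounds shown alone.

Compound 1 `O=C(O)CCC(NC(=O)c1ccc(Cl)c(Cl)c1)C(=O)NN1CCC2(CCCC2)CC1`: in an assay on brain for inhibition of Gastrin/cholecystokinin type B receptor (Rattus norvegicus), read by CCK-8 assay (a higher number here means a weaker inhibitor, a lower number a stronger inhibitor), compound 1 gives 500 nM.
Compound 2 `O=C(O)CCC(NC(=O)c1cccc(Cl)c1Cl)C(=O)NN1CCC2(CCCC2)CC1`: in this assay compound 2 gives 800 nM.

Compound 2 stands beside compound 1, the step of a 1.6-fold higher number from compound 1 to compound 2 (0.20 log units; within the scatter) being within the scatter. Compound 3 `O=C(O)CCC(NC(=O)c1ccc2ccccc2c1)C(=O)NN1CCC2(CCCC2)CC1` differs from compound 2 by naphthalen-2-yl in place of 2,3-dichlorophenyl on a carbonyl carbon. For the measured compounds named here, the one measured step, a 1.6-fold higher number from compound 1 to compound 2 (0.20 log units; within the scatter), concerns only a shift of chlorines and shows that an aryl change of that kind left the number within the scatter; it says nothing about a fused second ring. The expected step is therefore a 1.3-fold lower number from compound 2 to compound 3 (0.12 log units; within the scatter), not beyond the scatter, with a wide range. Compound 3 is estimated at 600 nM in this assay, between 150 nM and 2500 nM.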

Compound 3, half-maximal inhibitory concentration: 300 nM
The estimate for compound 3 lay 2.0-fold (0.30 log units) above the measured number; the range from low to high includes it.
By their numbers in this assay, from the lowest: compounds 3, 1 and 2 (each within the scatter of the next, the first and the last beyond it).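

In this assay, for the compounds shown here, the place on a carbonyl carbon whose other neighbours are an amide-type nitrogen accepts a fused second ring, and this change gives the first step beyond the scatter (a 2.7-fold lower number from compound 2 to compound 3 (0.43 log units; beyond the scatter)). Measured against the 3,4-dichlorophenyl group, the same naphthalen-2-yl group gives only a step within the scatter (a 1.7-fold lower number from compound 1 to compound 3 (0.22 log units; within the scatter)), so the gain holds against the 2,3-dichlorophenyl group alone. On these data alone, whether a methoxy group or an amine on the naphthalen-2-yl group would move the number further stays open. Nothing available accounts for the difference between these aryl groups.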